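The compounds below may be only part of what the source reports. "The series", "measured", "known", "first", "only" and "open" are said of these compounds alone.

In a functional assay on HEL cells (Homo sapiens) for cytotoxicity (a lower number here means that less compound is tolerated, a higher number that more compound is tolerated), compound 2 `CCCCCCC#Cc1cc2cn([C@@H]3O[C@H](CO)[C@@H](O)[C@@H]3O)c(=O)nc2o1` stands at > 53000 nM as a limit and not a number. The change to compound 3 `CCCCCCC#Cc1cc2cn(C)c(=O)nc2o1` is methyl in place of 3,4-dihydroxy-5-(hydroxymethyl)oxolan-2-yl on an aromatic nitrogen. Compound 1 `CCCCCCCCCCC#Cc1cc2cn(C)c(=O)nc2o1` also carries methyl on that nitrogen and stands at > 150000 nM as a limit too. Resting on compound 1 at > 150000 nM as a limit, the expectation in this assay is a small move toward more compound tolerated, not beyond the scatter. The estimated step (a step that the limit leaves unreadable from compound 2 to compound 3) is of that size. Compound 3 is expected at 90000 nM with an estimated range from 35000 nM to 230000 nM overall.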

Compound 3, half-maximal cytotoxic concentration: > 194000 nM
Compound 3: no number, only a limit; the forecaster's own chance of this, stated with the estimate: 75%; at least 2.1-fold (0.33 log units) between middle value and limit.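

Going by these compounds alone, compound 1, compound 2 and compound 3 all stand only as limits in this assay, so no step among them can be read. The compounds shown leave open whether either structural change shifts the cytotoxic concentration at all.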